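The source may report more compounds than this note shows. Statements on the series, on what has been measured and on what is new or still open speak of the compounds shown alone.

The measured compounds:
Compound 1 `Cc1ccc(Cn2cc(COc3ccc4c(=O)ccoc4c3)nn2)cc1`: 10400 nM
Compound 2 `O=c1ccoc2cc(OCc3cn(Cc4ccc([N+](=O)[O-])cc4)nn3)ccc12`: 19300 nM
Compound 3 `O=c1ccoc2cc(OCc3cn(Cc4ccccc4Cl)nn3)ccc12`: 23500 nM

These three share one core and differ only in the group on the saturated chain carbon bound to the aromatic nitrogen. In a functional assay on SW480 cells (Homo sapiens) for cytotoxicity, read by MTT assay, with a stated time of 48 h (on this read-out higher numbers stand for weaker inhibition and lower numbers for stronger inhibition), compound 3 stands apart from compound 1 by a 2.3-fold higher number from compound 1 to compound 3 (0.35 log units; beyond the scatter), while its number and that of compound 2 are separated only by a 1.2-fold higher number from compound 2 to compound 3 (0.09 log units; within the scatter). Compound 1 and compound 2 in turn differ by a 1.9-fold higher number from compound 1 to compound 2 (0.27 log units; within the scatter).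

Compound 4 `O=c1ccoc2cc(OCc3cn(Cc4cccc([N+](=O)[O-])c4)nn3)ccc12` is the next member of the series; the change from compound 3 is 3-nitrophenyl in place of 2-chlorophenyl on a saturated chain carbon bound to an aromatic nitrogen. The step that bears on this change most directly is a 1.2-fold higher number from compound 2 to compound 3 (0.09 log units; within the scatter), which exchanges another nitrophenyl group for the same 2-chlorophenyl and lies within the scatter; a 2.3-fold higher number from compound 1 to compound 3 (0.35 log units; beyond the scatter) shows a modest but real movement when a 4-methylphenyl is exchanged. Within the data shown here, no measured pair compares a 3-nitrophenyl with any other group, so the expectation rests on compound 2 and compound 3. Compound 4 is therefore expected to shift by a 1.2-fold lower number from compound 3 to compound 4 (0.07 log units; within the scatter), a step within the scatter toward a lower number. In this assay compound 4 is estimated at 20000 nM, with a range from 10000 nM to 40000 nM.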

Compound 4, half-maximal inhibitory concentration: > 100000 nM
Compound 4 was reported as a limit; the forecaster's own chance of this, stated with the estimate: 5%; middle value at least 5.0-fold (0.69 log units) away from the limit.
By their numbers in this assay, from the lowest: compounds 1, 2 and 3 (each within the scatter of the next, the first and the last beyond it). At a limit, above all of these: compound 4.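

In this assay compound 4 is reported only as a limit, not as a number: the limit of > 100000 nM in this assay, at which 1 of the 4 values shown sits. Among these compounds, the sharpest contrast is between the two nitrophenyl groups, an at least 5.1-fold higher number from compound 2 to compound 4 (0.71 log units; beyond the scatter), so the 4-nitrophenyl and 3-nitrophenyl compounds cannot be treated as interchangeable, although the earlier compounds alone gave no sign of this. Compounds 1, 2 and 3 had suggested that the saturated chain carbon bound to an aromatic nitrogen accepts different aryl groups with modest movement, but an at least 4.2-fold higher number from compound 3 to compound 4 (0.62 log units; beyond the scatter) and an at least 9.6-fold higher number from compound 1 to compound 4 (0.98 log units; beyond the scatter) show that a change in this place can move the number much further than that spread implied.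

The compounds shown leave open whether this loss belongs to the 3-nitrophenyl group in particular or extends to other groups carrying a substituent at that ring carbon, such as 3-chlorophenyl, 3-methylphenyl or 3-aminophenyl. Because compound 4 stands at a limit, the full size of all three steps also remains unknown, and the data give no cause for the change.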